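Cyclohexyl for Methyl in Two Related Guanidines

The source may hold more compounds than are shown below. What is called first, only, known or untested is meant among the compounds shown, and "the series" means these compounds.

Compound 1 `CN/C(=N\CCC(c1ccc(Br)cc1)c1ccccn1)NCCCc1c[nH]cn1` was tested in a functional assay on cardiac atrium for agonist activity at histamine H2 receptor (Cavia porcellus) (a higher number here means a more potent compound, by a factor of ten per unit of this negative logarithm, a lower number a less potent compound), where compound 1 gives 5.75. Compound 2 `Brc1ccc(C(CC/N=C(/NCCCc2c[nH]cn2)NC2CCCCC2)c2ccccn2)cc1` carries cyclohexyl in place of methyl on an amine nitrogen, and in this assay compound 2 gives 4.69, so that the step of a number 1.06 log units lower from compound 1 to compound 2 (beyond the scatter). Compound 3 `CN/C(=N\CCCC(c1ccc(Cl)c(Cl)c1)c1ccccn1)NCCCc1c[nH]cn1` has a different core; the difference between the two cores is not broken down here. In this assay compound 3 gives 5.58. Compound 4 `Clc1ccc(C(CCC/N=C(/NCCCc2c[nH]cn2)NC2CCCCC2)c2ccccn2)cc1Cl` is compound 3 with the same change, (cyclohexyl in place of methyl on an amine nitrogen), made at the same place as before. Because the earlier step of a number 1.06 log units lower from compound 1 to compound 2 (beyond the scatter) was large, a step of about the same size is expected here, a number 0.98 log units lower from compound 3 to compound 4 (beyond the scatter). The value of compound 4 in this assay is therefore estimated at 4.6, expected to lie between 4.1 and 5.1.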

Compound 4, negative logarithm of the half-maximal effective concentration: 4.65
The estimate for compound 4 lay 0.05 log units below the measured number, and the stated range covers the measured number.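

Cyclohexyl in place of methyl on an amine nitrogen brings a number 0.93 log units lower from compound 3 to compound 4 (beyond the scatter) in this assay and the change reads much the same on both cores: the same change on two cores in this assay, a number 1.06 log units lower (beyond the scatter) from compound 1 to compound 2 and a number 0.93 log units lower (beyond the scatter) from compound 3 to compound 4, 0.13 log units apart, within the scatter of two such steps

For these two pairs, then, the drop in potency carries over from one core to the other. It does not show that the drop would carry over to any further core, and the two pairs do not say why potency falls.

Going by these compounds, whether another group on the same amine nitrogen, such as ethyl or benzyl, would cost as much remains open. So does whether a core with a still longer chain would show a step of the same size.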